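Swapping a methyl for a fluoro on an aryl sulfone

This account rests on a few compounds, and the source may have more. Where it says the series, first, only, none or still open, it means among the compounds named here.

Compounds measured so far:
compound 1, `O=C(NCc1ccc(S(=O)(=O)N2CCCCC2)cc1)c1cc2cnccc2s1`, 1600 nM
compound 2, `Cc1cccc(S(=O)(=O)c2ccc(CNC(=O)c3cc4cnccc4[nH]3)cc2)c1`, 4 nM
compound 3, `O=C(NCc1ccc(S(=O)(=O)N2CCCCC2)cc1)c1cc2cnccc2o1`, 1500 nM

In a functional assay on A2780 cells (Homo sapiens) for inhibition, read by sulforhodamine B assay, with a stated time of 72 h (a lower number here means a stronger inhibitor, a higher number a weaker inhibitor), compound 2 gives the lowest number of the three, and its distance to both compound 1 and compound 3 lies beyond the scatter, so it is the most potent compound in this set. Compound 4, `O=C(NCc1ccc(S(=O)(=O)c2cccc(F)c2)cc1)c1cc2cnccc2[nH]1`, is a close relative of compound 2, differing only in fluoro in place of methyl on an aromatic carbon.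

Going by the values given here, the one measured step, a 1.1-fold lower number from compound 1 to compound 3 (0.03 log units; within the scatter), concerns the shared core and not the aryl sulfone, so no measured step bears directly on the change from compound 2 to compound 4. The change is small in size and both groups are uncharged with no donors or acceptors. With nothing to point either way, no step beyond the scatter is expected in this assay .

Compound 4 is therefore estimated at 5 nM, with a range from 1.5 nM to 16 nM, a step of a 1.3-fold higher number from compound 2 to compound 4 (0.10 log units; within the scatter) that is expected to stay within the scatter.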

Compound 4, half-maximal inhibitory concentration: 11 nM
Compound 4: middle estimate off by 2.2-fold (0.34 log units), on the low side; measured number inside the range.
By their numbers in this assay, from the lowest: compound 2; then compound 4; then compounds 3 and 1 (each within the scatter of the next).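

In this assay, the position on the aryl sulfone proves sensitive to the exchange of a single heavy atom: fluoro in place of methyl gives a 2.8-fold higher number from compound 2 to compound 4 (0.44 log units; beyond the scatter), a modest step but one that lies beyond the scatter. Going by these compounds alone, no earlier step touched this ring, so this is the first sign that the 3-methylphenyl and 3-fluorophenyl groups are not interchangeable here, even though neither group carries a hydrogen-bond donor, a hydrogen-bond acceptor or a net charge. Nothing among the data offers an explanation for this step.

The compounds shown leave open how a chloro group, a methoxy group or an amine at this position would compare with methyl and fluoro. They also leave open whether the same exchange would give a similar step on a different core.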